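The source may hold more compounds than are shown below. What is called first, only, known or untested is meant among the compounds shown, and "the series" means these compounds.

Measured so far in a functional assay on A549 cells (Homo sapiens) for inhibition, read by CCK-8 assay, with a stated time of 72 h, tested at 8 uM; on this read-out higher numbers stand for more inhibition of growth at the one concentration tested and lower numbers for less inhibition of growth:
- compound 1 `Nc1ccccc1NC(=O)/C=C/c1ccc(CSc2ccc(C(F)(F)F)cn2)cc1`: 56.5%
- compound 2 `Cc1ccc(SCc2ccc(/C=C/C(=O)Nc3ccccc3N)cc2)cc1`: 48.3%
- compound 3 `Nc1ccccc1NC(=O)/C=C/c1ccc(CSc2ccc(F)cc2)cc1`: 59.1%

In this assay, compound 3 gives 59.1%, which places it at the upper edge of this small set, together with compound 1. The comparison with its neighbours reads a number 2.6 percentage points higher from compound 1 to compound 3 (within the scatter) and a number 10.8 percentage points higher from compound 2 to compound 3 (beyond the scatter).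

The next structure is compound 4 `Nc1ccccc1NC(=O)/C=C/c1ccc(CSCCc2ccccc2)cc1`, which has phenethyl in place of 4-fluorophenyl on a sulfur. The measured steps that bear on this change also swap the group on the sulfur, and they are small: one is a number 8.2 percentage points lower from compound 1 to compound 2 (within the scatter), and the two above are of similar size. None of them introduces phenethyl, so they offer only a loose guide, and the range must stay wide.

Compound 3 starts from the upper edge at 59.1%, so a modest fall seems more likely than a rise. The expected change is a number 9.1 percentage points lower from compound 3 to compound 4 (within the scatter). For compound 4 the estimated value is 50%, with an expected range of 33% to 66%.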

Compound 4, percent growth inhibition at one concentration: 50.3%
Compound 4: middle estimate off by 0.3 percentage points, on the low side, within the range that was stated.
By their numbers in this assay, from the lowest: compounds 2, 4, 1 and 3 (each within the scatter of the next, the first and the last beyond it).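

In this assay the three new steps are a number 8.8 percentage points lower from compound 3 to compound 4 (within the scatter) and a number 2 percentage points higher from compound 2 to compound 4 (within the scatter) and a number 6.2 percentage points lower from compound 1 to compound 4 (within the scatter) and each of them stays within the usual scatter. Phenethyl is the first group in this set that does not carry its aromatic ring straight on the sulfur, and this change leaves the read-out indistinguishable from that of each of the three earlier compounds, even though compound 2 and compound 3 differ from each other beyond the scatter. No measurement is available that could explain this result.

From the compounds shown here alone, what remains open is whether an aromatic ring on this chain matters at all, which a plain alkyl chain could test. An amine or a carboxylic acid at the end of the chain, or a longer chain carrying the phenyl ring, also remains to be seen.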